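Aryl exchange from compound 3 to compound 4

A few compounds are considered here, and "the series" means these few. Any claim that something is new, unique, unknown or untested is made for them only; others in the source may bear on it.

Measured so far:
compound 1 `O=C(CSc1nc(Nc2ccccc2)c2ccccc2n1)Nc1cccc(F)c1` gives 6790 nM in a functional assay on NCI-H1975 cells (Homo sapiens) for inhibition, read by MTT assay, with a stated time of 72 h; a higher number here means a weaker inhibitor, a lower number a stronger inhibitor;
compound 2 `CCc1ccc(NC(=O)CSc2nc(Nc3ccccc3)c3ccccc3n2)cc1` gives 9910 nM;
compound 3 `C=CC(=O)Nc1cccc(NC(=O)CSc2nc(Nc3cccc(Br)c3)c3ccccc3n2)c1` gives 12100 nM.

All three numbers lie within the scatter of one another, and compound 3 sits at the upper edge of that cluster without separating from compound 2 or compound 1. Compound 4 `C=CC(=O)Nc1cccc(NC(=O)CSc2nc(Nc3ccc(CC)cc3)c3ccccc3n2)c1` differs from compound 3 by 4-ethylphenyl in place of 3-bromophenyl on a nitrogen on an aromatic ring. Going by the values given here, the one measured step that resembles this change, a 1.5-fold higher number from compound 1 to compound 2 (0.16 log units; within the scatter), moved the same kind of aryl group but on an amide-type nitrogen and stayed within the scatter. Among the compounds with values here, no step at the nitrogen on the aromatic ring has been measured. Compound 4 is therefore expected to shift by a 1.1-fold higher number from compound 3 to compound 4 (0.03 log units; within the scatter), not beyond the scatter. Compound 4 is estimated at 13000 nM, with a range of 5000 nM to 35000 nM.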

Compound 4, half-maximal inhibitory concentration: 8270 nM
Compound 4: the middle estimate sits 1.6-fold (0.20 log units) above what was measured; the range from low to high includes it.
By their numbers in this assay, from the lowest: compounds 1, 4, 2 and 3 (each within the scatter of the next).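

In this assay, going by these compounds alone, the exchange of 3-bromophenyl for 4-ethylphenyl on a nitrogen on an aromatic ring gives a 1.5-fold lower number from compound 3 to compound 4 (0.17 log units; within the scatter) and is the first step read at this position. Like the exchange on the amide-type nitrogen, which gave a 1.5-fold higher number from compound 1 to compound 2 (0.16 log units; within the scatter) and also stayed within the scatter, it does not separate the two compounds. No evidence is available that bears on this result. Still open, going by these compounds, is whether a phenyl group carrying an amine or a carboxylic acid on this nitrogen would leave the scatter. The same holds for a longer chain in place of the ethyl group.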